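Hydroxy in place of hydrogen on compound 1

The source may hold more compounds than are shown below. What is called first, only, known or untested is meant among the compounds shown, and "the series" means these compounds.

Among the compounds with values here, compound 1 (`COC(=O)c1cc(CCc2ccccc2OC)ccc1O`) holds the higher of the two numbers measured so far in a functional assay on HaCaT cells (Homo sapiens) for antiproliferative activity, read by sulforhodamine B assay, with a stated time of 3 days (a lower number here means a stronger inhibitor, a higher number a weaker inhibitor), where compound 1 gives 20000 nM. In this assay, compound 2 (`COC(=O)c1cc(CCc2c(OC)cccc2OC)ccc1O`) gives 110 nM.

Compound 3 (`COC(=O)c1cc(CCc2cc(O)ccc2OC)ccc1O`) keeps the core of compound 1 and adds hydroxy in place of hydrogen on an aromatic carbon, meta to a large group and para to a methoxy group: hydroxy in place of hydrogen on an aromatic carbon.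

Within the data shown here, only one measured step bears on this change. It is large and beyond the scatter: a 180-fold lower number from compound 1 to compound 2 (2.26 log units; beyond the scatter), with methoxy in place of hydrogen on an aromatic carbon. Among the measured compounds shown here, that single step also involves a different entering group, and no measured compound shows what a hydroxy does. It therefore supports the direction only tentatively and does not set the size.

A lower number is expected, though a smaller change than in that step, and the estimated step is a 6.7-fold lower number from compound 1 to compound 3 (0.82 log units; beyond the scatter). For compound 3 the estimated value is 3000 nM, with an expected range of 300 nM to 25000 nM.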

Compound 3, half-maximal inhibitory concentration: 8700 nM
For compound 3 the middle estimate is 2.9-fold (0.46 log units) below the measured one, and the stated range covers the measured number.
By their numbers in this assay, from the lowest: compound 2; then compound 3; then compound 1.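

The carbon meta to a large group and para to a methoxy group now has a measured reading in this assay and hydroxy there gives a 2.3-fold lower number from compound 1 to compound 3 (0.36 log units; beyond the scatter) as a real but modest gain over the parent. Within the data shown here, this is the first hydroxy measured, and its step is far smaller than a 180-fold lower number from compound 1 to compound 2 (2.26 log units; beyond the scatter) with methoxy as the entering group, so a new oxygen-bearing group on an aromatic carbon does not by itself bring a drop of the larger size. No measurement at hand accounts for the difference in size between these two steps.

The two steps differ in both the entering group and its place, so the compounds shown cannot separate the effect of hydroxy versus methoxy from the effect of where the group sits. Also open, on these data alone, is how a methoxy, an amine or a carboxylic acid at this same carbon would compare, and whether any of them would come closer to the modest step or to the large one.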